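This account rests on a few compounds, and the source may have more. Where it says the series, first, only, none or still open, it means among the compounds named here.

Two compounds carry numbers in an assay on membranes from CHO cells for displacement of a labelled ligand from adenosine receptor A1 (Homo sapiens), read by scintillation counting, with a stated time of 60 min, tested at 1 uM (on this read-out higher numbers stand for more inhibition at the one concentration tested (going by the name of the read-out) and lower numbers for less inhibition), so far. Compound 2, `COC(=O)C1=C(C)NC(=S)NC1c1ccoc1`, stands highest of the two, and in this assay compound 2 gives 25%. Its nearest neighbour is compound 1, `CC1=C(C(=O)OC(C)(C)C)C(c2ccsc2)NC(=O)N1`, which in this assay gives 15%. The gap between these two numbers falls within the scatter of the measurement, so the pair shows no separation and no order can be read from it. Compound 3, `CC1=C(C(=O)OCc2ccccc2)C(c2ccoc2)NC(=S)N1`, has not yet been measured. It differs from compound 2 in one place: phenyl in place of hydrogen on a saturated chain carbon bound to an oxygen next to a carbonyl group. Within the data shown here, no step between measured compounds bears on this change, since compound 1 and compound 2 differ from each other in several places at once. Compound 3 is therefore estimated to give 30% in this assay, with a range from 5% to 60%. The expected step is a number 5 percentage points higher from compound 2 to compound 3 (within the scatter), which would not rise beyond the scatter in either direction.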

Compound 3, a percentage reported as inhibition, at one concentration (the size of the read-out at that concentration, not a potency): 25%
Estimate against measurement, compound 3: 5 percentage points above; measured number inside the range.
By their numbers in this assay, from the lowest: compounds 1, 2 and 3 (each within the scatter of the next).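

In this assay, the swap of phenyl for hydrogen on a saturated chain carbon bound to an oxygen next to a carbonyl group, which turns methyl into benzyl, gives no change at the digits printed from compound 2 to compound 3 (within the scatter) at this position. Among these compounds, this is the first comparison that changes one place only, and it shows that this position can carry the six heavy atoms of phenyl with no separation from hydrogen on this read-out. Nothing available explains this outcome.

As far as these compounds go, whether the same holds for other groups at this position stays open, for instance an amine, a carboxylic acid or a longer chain in place of phenyl. From the compounds shown here alone, it is also open whether benzyl would behave the same way on a different core, as this rests on a single pair of compounds.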